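The compounds below may be only part of what the source reports. "The series", "measured", "known", "first", "only" and "open" are said of these compounds alone.

Measured in an in vitro ADME assay on microsomes from liver (Mus musculus) for pharmacokinetics, read by LC-MS, with a stated time of 10 min, tested at 1 uM; a lower number here means slower removal, a higher number faster removal of the compound:
- compound 1 `CN1C[C@H](C(=O)Nc2ccc(C(F)(F)F)cc2)[C@@H](c2ccc(/C=C/C(=O)Nc3ccccc3N)cc2)C1`: 23 mL/min/kg
- compound 2 `CN1C[C@H](C(=O)Nc2ccc(Cl)c(Cl)c2)[C@@H](c2ccc(/C=C/C(=O)Nc3ccccc3N)cc2)C1`: 36 mL/min/kg
- compound 3 `CN1C[C@H](C(=O)Nc2cccnc2)[C@@H](c2ccc(/C=C/C(=O)Nc3ccccc3N)cc2)C1`: 41 mL/min/kg

Compound 3 stands level with the other two, as both of its steps lie within the scatter: a 1.8-fold higher number from compound 1 to compound 3 (0.25 log units; within the scatter) and a 1.1-fold higher number from compound 2 to compound 3 (0.06 log units; within the scatter).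

The next compound, compound 4 `CN1C[C@H](C(=O)N2CCCCC2)[C@@H](c2ccc(/C=C/C(=O)Nc3ccccc3N)cc2)C1`, carries a larger change: piperidin-1-yl in place of (pyridin-3-yl)amino on a carbonyl carbon. Here piperidin-1-yl sits in place of (pyridin-3-yl)amino on a carbonyl carbon, so a non-aromatic ring replaces an aromatic one and the hydrogen-bond donor is gone.

Going by the values given here, three measured steps touch this same part of the molecule: a 1.6-fold higher number from compound 1 to compound 2 (0.19 log units; within the scatter), a 1.8-fold higher number from compound 1 to compound 3 (0.25 log units; within the scatter) and a 1.1-fold higher number from compound 2 to compound 3 (0.06 log units; within the scatter). All stayed within the scatter, yet each only swapped one aromatic group for another on an amide-type nitrogen. None tests a piperidin-1-yl, so they are a loose guide and give no direction.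

The expectation is therefore no step beyond the scatter, and the estimate means a 1.1-fold lower number from compound 3 to compound 4 (0.03 log units; within the scatter). For compound 4 the estimated value is 38 mL/min/kg, with an expected range of 19 mL/min/kg to 75 mL/min/kg.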

Compound 4, clearance: 42 mL/min/kg
Compound 4: middle estimate off by 1.1-fold (0.04 log units), on the low side, and the stated range covers the measured number.
By their numbers in this assay, from the lowest: compounds 1, 2, 3 and 4 (each within the scatter of the next).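

In this assay, going by these compounds alone, the earlier steps only exchanged one aromatic group for another, whereas compound 4 puts a non-aromatic ring, piperidin-1-yl, on the carbonyl carbon and loses the amide hydrogen. Even this larger change leaves all four compounds level, with a 1.0-fold higher number from compound 3 to compound 4 (0.01 log units; within the scatter) and a 1.2-fold higher number from compound 2 to compound 4 (0.07 log units; within the scatter) and a 1.8-fold higher number from compound 1 to compound 4 (0.26 log units; within the scatter) as the three new steps, so among these compounds neither the aromatic ring nor the amide hydrogen at this position shows any link to the clearance number. Nothing measured here explains this lack of difference.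

As far as these compounds go, it remains open whether a morpholine ring, a simple dimethylamino group or a carboxylic acid on this carbonyl carbon would also stay level. Which part of the molecule the microsomes act on also stays unknown.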